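Trading a Ring for a Chain on the Thiocarbonyl Carbon

The source may hold more compounds than are shown below. What is called first, only, known or untested is meant among the compounds shown, and "the series" means these compounds.

In a functional assay on K562 cells (Homo sapiens) for cytotoxicity, read by MTT assay, with a stated time of 72 h (a higher number here means a weaker inhibitor, a lower number a stronger inhibitor), compound 1 (`CC(C)(C)NC(=S)N/N=C1\CC(c2ccc(O)cc2)Oc2cc(O)ccc21`) gives 8900 nM, compound 2 (`CCCCNC(=S)N/N=C1\CC(c2ccc(O)cc2)Oc2cc(O)ccc21`) gives 17000 nM and compound 3 (`Oc1ccc(C2C/C(=N\NC(=S)N3CCCCC3)c3ccc(O)cc3O2)cc1`) gives 13700 nM. Compound 3 cannot be told apart from the other two, as the steps show: a 1.5-fold higher number from compound 1 to compound 3 (0.19 log units; within the scatter) and a 1.2-fold lower number from compound 2 to compound 3 (0.09 log units; within the scatter). Compound 4 (`CCCNC(=S)N/N=C1\CC(c2ccc(O)cc2)Oc2cc(O)ccc21`) has not been measured. It differs from compound 3 by propylamino in place of piperidin-1-yl on a thiocarbonyl carbon. For the measured compounds named here, the closest precedent is compound 2, which carries butylamino there, and its step to the ring was small: a 1.2-fold lower number from compound 2 to compound 3 (0.09 log units; within the scatter). Changing the chain also stayed small: a 1.9-fold higher number from compound 1 to compound 2 (0.28 log units; within the scatter). So in this assay no change beyond the scatter is expected, only a 1.1-fold higher number from compound 3 to compound 4 (0.04 log units; within the scatter). For compound 4 the estimated value is 15000 nM, with an expected range of 8000 nM to 28000 nM.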

Compound 4, half-maximal inhibitory concentration: 31000 nM
The estimate for compound 4 lay 2.1-fold (0.32 log units) below the measured number; measured number outside the range, above it.
By their numbers in this assay, from the lowest: compounds 1, 3, 2 and 4 (each within the scatter of the next, the first and the last beyond it).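

In this assay, for the compounds shown here, propylamino in place of piperidin-1-yl on the thiocarbonyl carbon is the first ring-to-chain step to pass beyond the scatter, though it remains modest (a 2.3-fold higher number from compound 3 to compound 4 (0.35 log units; beyond the scatter)). Propyl in place of tert-butyl also clears the scatter (a 3.5-fold higher number from compound 1 to compound 4 (0.54 log units; beyond the scatter)), whereas propyl and butyl cannot be told apart (a 1.8-fold higher number from compound 2 to compound 4 (0.26 log units; within the scatter)), so the chains shown do not all behave alike. Nothing available explains these steps.

From the compounds shown here alone, whether a longer chain such as hexyl, or a morpholine ring, on this carbon would give a lower or higher number remains open.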